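Thiazolyl on the Amino Nitrogen: an Expected Gain

The compounds below may be only part of what the source reports. "The series", "measured", "known", "first", "only" and "open" are said of these compounds alone.

Measured so far, in an assay on isolated protein for inhibition of complement C1r subcomponent (Homo sapiens); on this read-out higher numbers stand for weaker inhibition and lower numbers for stronger inhibition:
Compound 1 `Nc1nc2ccccc2c(=O)o1` gives > 62500 nM, which is a limit of the assay and not a number.
Compound 2 `Cc1cccc2nc(NC(C)C)oc(=O)c12` gives > 62500 nM, also a limit of the assay.
Compound 3 `O=c1oc(Nc2ccccc2Br)nc2ccccc12` gives 5100 nM.

Compound 1 is the simplest of the three, carrying a bare amino group on the shared core. On the numbers shown, compound 1 stands at the limit of this assay, as does compound 2 (the limit of > 62500 nM in this assay, at which 2 of the 3 values shown sit); only compound 3, which bears a brominated aryl ring on that amino nitrogen, returns a measured number.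

Compound 4 `O=c1oc(Nc2nccs2)nc2ccccc12` has not yet been measured. It differs from compound 1 by 1,3-thiazol-2-yl in place of hydrogen on a nitrogen on an aromatic ring. Among the compounds with values here, no pair of measured compounds differs in exactly one place, so no measured step is available for comparison. Still, a step toward stronger inhibition, beyond the usual scatter, is expected, because compound 3 gives 5100 nM with a ring attached at that same nitrogen. Compound 1, with hydrogen there, returns only a limit of the assay.

For compound 4 the expected value in this assay is 15000 nM, with a range from 4000 nM to 60000 nM. The estimated step is an at least 4.1-fold lower number from compound 1 to compound 4 (0.61 log units; beyond the scatter), toward stronger inhibition.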

Compound 4, half-maximal inhibitory concentration: > 62500 nM
Compound 4 gave a limit, no number; the forecaster's own chance of this, stated with the estimate: 35%; at least 4.1-fold (0.61 log units) between middle value and limit.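

Compound 1 and compound 4 each return only a limit in this assay, not a number, and the step between them cannot be read: the limit of > 62500 nM in this assay, at which 3 of the 4 values shown sit. Still open, going by these compounds, is how far 1,3-thiazol-2-yl in place of hydrogen on that nitrogen moves inhibition, and which other rings there would give a measured number.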